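Cyano for Methyl on the Aryl of a Piperidine Acetanilide

The compounds below may be only part of what the source reports. "The series", "measured", "known", "first", "only" and "open" are said of these compounds alone.

Measured compounds:
compound 1, `Cc1cccc(NC(=O)CN2CCC(c3ccc(O)cc3)CC2)c1`, 70 nM
compound 2, `Cc1cccc(NC(=O)CN2CCC(c3ccccc3C)CC2)c1`, 340 nM

Of the two numbers in a functional assay on HEK293 cells for agonist activity at D(4) dopamine receptor (Homo sapiens), read by FLIPR (a higher number here means that more compound is needed for the effect, a lower number that less compound is needed), compound 2 holds the highest, set apart from compound 1 by the step of a 4.9-fold higher number from compound 1 to compound 2 (0.69 log units; beyond the scatter). Compound 3 `Cc1cccc(NC(=O)CN2CCC(c3ccccc3C#N)CC2)c1` differs from compound 2 by cyano in place of methyl on an aromatic carbon. No measured step exchanges a substituent on this aromatic carbon; the only step shown swaps the whole aryl group and so does not bear on this change. With nothing pointing either way, the step of a 1.1-fold lower number from compound 2 to compound 3 (0.05 log units; within the scatter) is expected to stay within the scatter. For compound 3 the estimate in this assay is 300 nM, between 90 nM and 1000 nM.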

Compound 3, half-maximal effective concentration: 8 nM
Compound 3: the middle estimate sits 38-fold (1.57 log units) above what was measured, and the stated range ends above it.
By their numbers in this assay, from the lowest: compound 3; then compound 1; then compound 2.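

In this assay, cyano and methyl are not interchangeable on this aromatic carbon: the exchange gives a 43-fold lower number from compound 2 to compound 3 (1.63 log units; beyond the scatter), so the outcome depends strongly on the group held here. The 2-cyanophenyl group also goes beyond the 4-hydroxyphenyl group, with an 8.8-fold lower number from compound 1 to compound 3 (0.94 log units; beyond the scatter), which leaves compound 3 with the lowest number of the three.

As far as these compounds go, whether a chloro, methoxy or carboxamide group on this carbon would give a similar result remains open, as does the effect of a cyano group elsewhere on the aromatic ring. No evidence at hand bears on what lies behind this step.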